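One Measured Value and a Halogen Swap

A few compounds are considered here, and "the series" means these few. Any claim that something is new, unique, unknown or untested is made for them only; others in the source may bear on it.

Compound 3 `O=C(Nc1ccc(S(=O)(=O)Nc2ccccc2)cc1)c1ccc(Br)cc1F`: 67%
Compound 1 `O=C(Nc1cccc(S(=O)(=O)Nc2ccccc2)c1)c1ccc(Cl)cc1Cl`: "not determined" (no result reported)
Compound 2 `O=C(Nc1ccc(S(=O)(=O)NCc2ccccc2)cc1)c1ccc(Cl)cc1Cl`: "not determined" (no result reported)

Of the three compounds whose structures are in hand, only compound 3 carries a number. In a functional assay on HEK293 cells for agonist activity at probable G-protein coupled receptor 27 (Homo sapiens), read by a luciferase reporter and beta-arrestin recruitment, with a stated time of 10 min (on this read-out lower numbers stand for smaller maximal responses and higher numbers for larger maximal responses), compound 3 gives 67%. Among the compounds with values here, compound 1 and compound 2 were not determined in this assay, so no step between measured compounds can be drawn, and where compound 3 stands can be said only in the plain sense that it holds the single value recorded.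

Compound 4 `O=C(Nc1ccc(S(=O)(=O)Nc2ccccc2)cc1)c1ccc(I)cc1F` has not been measured. It differs from compound 3 in one place: iodo in place of bromo on an aromatic carbon. Cut one bond further out, the change reads 4-bromo-2-fluorophenyl to 2-fluoro-4-iodophenyl.

Within the data shown here, with no step between measured compounds to lean on, the expectation rests on the change itself, one heavy atom leaving and one entering, with no ring, no hydrogen-bond donor or acceptor and no charge involved. The size of step expected in this assay is none beyond the usual scatter, in either direction. The expected step is no change at the digits printed from compound 3 to compound 4 (within the scatter). Compound 4 is therefore estimated to give about 67% in this assay, with a range from 45% to 85%.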

Compound 4, largest response reached (Emax), in percent of the reference or control that the assay uses: 36%
Compound 4: the middle estimate sits 31 percentage points above what was measured; the whole stated range lies above it.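

In this assay, within the data shown here, iodo in place of bromo on an aromatic carbon, meta to a fluoro group and para to a large group, gives a number 31 percentage points lower from compound 3 to compound 4 (beyond the scatter), the first step that can be read. Until now a single value stood alone, so nothing showed whether the maximal response was sensitive to the group at this position; it is now clear that it is, even for an exchange of one halogen for another with no ring, no hydrogen-bond donor or acceptor and no net charge on either side. Nothing at hand bears on why the response differs between these two compounds.

Going by these compounds, with only bromo and iodo to compare, this single step gives no direction for the position as a whole, and it remains open where a hydrogen, a methoxy group or a nitrile at the same place would fall in this assay. On these data alone, it is also open whether the same exchange would give a step of similar size with the fluoro group replaced or with a different group on the sulfonamide nitrogen.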